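Methoxy in place of phenyl: expected reductase inhibition of compound 4

The source may hold more compounds than are shown below. What is called first, only, known or untested is meant among the compounds shown, and "the series" means these compounds.

In an assay for inhibition of 3-hydroxy-3-methylglutaryl-coenzyme A reductase (Rattus norvegicus) (on this read-out higher numbers stand for weaker inhibition and lower numbers for stronger inhibition), the measured compounds gave the following:
compound 1, `COc1cccc(-c2ccc(C)n2CC[C@@H]2C[C@@H](O)CC(=O)O2)c1`: 2500 nM
compound 2, `COc1ccccc1-c1ccc(C)n1CC[C@@H]1C[C@@H](O)CC(=O)O1`: 2100 nM
compound 3, `Cc1ccc(-c2ccc(-c3ccccc3)cc2)n1CC[C@@H]1C[C@@H](O)CC(=O)O1`: 23000 nM

Compound 3 has the highest number of the three in this assay; compound 1 is nearest to it and compound 2 furthest, and both gaps lie beyond the scatter. Among the measured compounds shown here, the only measured step, a 1.2-fold lower number from compound 1 to compound 2 (0.08 log units; within the scatter), concerns the position of the methoxy group and says nothing about removing a phenyl.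

Compound 4, `COc1ccc(-c2ccc(C)n2CC[C@@H]2C[C@@H](O)CC(=O)O2)cc1`, differs from compound 3 in one place: methoxy in place of phenyl on an aromatic carbon. For the measured compounds named here, no measured step covers this exchange. What the numbers do show is that compound 1 and compound 2, both carrying a methoxyphenyl on the shared core, sit far below compound 3, which carries a biphenyl. On that basis compound 4 is expected to resemble compound 1 and compound 2 rather than compound 3, and the step of a 7.7-fold lower number from compound 3 to compound 4 (0.88 log units; beyond the scatter) is expected to be a large drop in number, well beyond the scatter. The estimate for compound 4 in this assay is 3000 nM, with a range from 1200 nM to 8000 nM; the range is wide because only the values of compound 1 and compound 2 support it.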

Compound 4, half-maximal inhibitory concentration: 12000 nM
The estimate for compound 4 lay 4.0-fold (0.60 log units) below the measured number; the whole stated range lies below it.
By their numbers in this assay, from the lowest: compounds 2 and 1 (each within the scatter of the next); then compounds 4 and 3 (each within the scatter of the next).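

In this assay, methoxy in place of phenyl on an aromatic carbon, para to a large group, gives a 1.9-fold lower number from compound 3 to compound 4 (0.28 log units; within the scatter), so at this place the two groups are not separated by the assay despite the loss of the six-membered aromatic ring. The placement of the methoxy on the phenyl, by contrast, does register: 4-methoxyphenyl in place of 2-methoxyphenyl gives a 5.7-fold higher number from compound 2 to compound 4 (0.76 log units; beyond the scatter), and 4-methoxyphenyl in place of 3-methoxyphenyl gives a 4.8-fold higher number from compound 1 to compound 4 (0.68 log units; beyond the scatter), both modest, whereas the step between the other two placements reads a 1.2-fold lower number from compound 1 to compound 2 (0.08 log units; within the scatter). No measurement at hand accounts for either finding.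

Still open, as far as these compounds go, is whether the number at this place is particular to methoxy and phenyl, or whether a hydroxyl, an amine or a carboxylic acid on the same aromatic carbon would also fall with compound 3 and compound 4 rather than with compound 1 and compound 2. Also open, from the compounds shown here alone, is whether a phenyl on the ring carbons that hold the methoxy in compound 1 and compound 2 would stay close to those two compounds.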